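The source may report more compounds than this note shows. Statements on the series, on what has been measured and on what is new or still open speak of the compounds shown alone.

Measured in a functional assay on A549 cells (Homo sapiens) for antiproliferative activity, read by MTT assay, with a stated time of 72 h; on this read-out lower numbers stand for stronger inhibition and higher numbers for weaker inhibition:
- compound 1 `Cc1ccc(N2C(=O)COc3ccc(-c4cnc5ccccc5c4)cc32)cc1`: > 40000 nM, a limit
- compound 2 `COc1ccc(N2C(=O)COc3ccc(-c4cnc5ccccc5c4)cc32)cc1`: > 40000 nM, a limit

Compound 2 is known only as a limit, > 40000 nM. Among the compounds with values here, the series so far rests on (the limit of > 40000 nM in this assay, at which 2 of the 2 values shown sit).

Compound 3 `O=C1COc2ccc(-c3cnc4ccccc4c3)cc2N1c1ccc(F)cc1` carries fluoro in place of methoxy on an aromatic carbon, with fluoro in place of methoxy on an aromatic carbon. Within the data shown here, the only measured step that bears on it is a step that the two limits leave unreadable from compound 1 to compound 2, which also changes a small group at this place but gives no size. No step beyond the scatter is therefore expected in this assay, and the value is expected to stay close to the limit. The estimated step is a number no higher from compound 2 to compound 3 (the limit leaves the size open). For compound 3 the expected value is 40000 nM, with an estimated range of 15000 nM to 80000 nM.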

Compound 3, half-maximal inhibitory concentration: > 40000 nM
Compound 3: only a limit was reported (the forecaster's own chance of this, stated with the estimate: 75%); the middle value sits exactly at the limit.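

No step can be read among compound 1, compound 2 and compound 3, since all three values are only limits: the limit of > 40000 nM in this assay, at which 3 of the 3 values shown sit. The compounds shown leave open whether in this assay methyl, methoxy and fluoro differ at all.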